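This account rests on a few compounds, and the source may have more. Where it says the series, first, only, none or still open, it means among the compounds named here.

Compounds measured so far:
compound 1, `CCCCOC(=O)NS(=O)(=O)c1ccc(CCC)cc1-c1ccc(Cn2c(C(C)(C)C)nc3ccccc32)cc1`: 5.3 nM
compound 2, `CCCc1ccc(S(=O)(=O)NC(=O)OCCCC(F)(F)F)c(-c2ccc(Cn3c(C(C)(C)C)nc4ccccc43)cc2)c1`: 4.5 nM

In an assay on membranes from HEK293 cells for displacement of a labelled ligand from Type-2 angiotensin II receptor (Homo sapiens), read by radioligand binding (a higher number here means a weaker inhibitor, a lower number a stronger inhibitor), compound 1 gives 5.3 nM and compound 2 gives 4.5 nM. Compound 2 has the lowest of the two numbers, but its nearest neighbour is compound 1, and the step between them, a 1.2-fold lower number from compound 1 to compound 2 (0.07 log units; within the scatter), lies within the scatter, so the two cannot be ranked.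

Compound 3, `CCCc1ccc(S(=O)(=O)NC(=O)OCCC(F)(F)C(F)(F)F)c(-c2ccc(Cn3c(C(C)(C)C)nc4ccccc43)cc2)c1`, differs from compound 2 in one place: 1,1,2,2,2-pentafluoroethyl in place of 2,2,2-trifluoroethyl on a saturated chain carbon, two bonds along the chain from an oxygen next to a carbonyl group. Within the data shown here, the only measured step that bears on this, a trifluoromethyl in place of methyl on the same chain, read a 1.2-fold lower number from compound 1 to compound 2 (0.07 log units; within the scatter), which is no change beyond the scatter. Adding two more fluorine atoms to that chain is therefore expected to leave the number roughly where it is, the expected step being no change at the digits printed from compound 2 to compound 3 (within the scatter). Compound 3 is estimated at 4.5 nM in this assay, within a range from 2.3 nM to 9 nM.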

Compound 3, inhibition constant: 6 nM
Compound 3: middle estimate off by 1.3-fold (0.12 log units), on the low side; the range from low to high includes it.
By their numbers in this assay, from the lowest: compounds 2, 1 and 3 (each within the scatter of the next).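

In this assay, the move to 1,1,2,2,2-pentafluoroethyl gives a 1.3-fold higher number from compound 2 to compound 3 (0.12 log units; within the scatter) and so adds a second fully fluorinated step at this place with no change beyond the scatter. Among these compounds, measured against the plain chain of compound 1, the same group gives a 1.1-fold higher number from compound 1 to compound 3 (0.05 log units; within the scatter) and this shows that the reading stays level across all three chain ends, which the single earlier step could not show. No measurement here explains why the reading stays level at this position.

From the compounds shown here alone, whether this level reading extends beyond fluorinated chains stays open, since a chain ending in an amine or a carboxylic acid, or a much longer chain, could read differently. Going by these compounds, all three compounds also share the same core, so it is unknown whether the chain behaves this way on any other core.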